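Pyrrolidinyl for Morpholinyl on a Thiocarbonyl Carbon

The source may hold more compounds than are shown below. What is called first, only, known or untested is meant among the compounds shown, and "the series" means these compounds.

Measured compounds:
compound 1 `COc1ccc2occ(CSC(=S)N3CCCC3)c(=O)c2c1` gives 3100 nM
compound 2 `O=c1c(CSC(=S)N2CCCC2)coc2cc(Cl)ccc12` gives 2100 nM
compound 3 `O=c1c(CSC(=S)N2CCOCC2)coc2ccccc12` gives 4400 nM

These three compounds were tested in a functional assay on HEp-2 cells (Homo sapiens) for antiproliferative activity, read by MTT assay, with a stated time of 72 h; on this read-out higher numbers stand for weaker inhibition and lower numbers for stronger inhibition. Compound 3 stands at the highest number of the three. Its nearest neighbour is compound 1, whose number lies within the scatter of repeated measurements, so no order between compound 3 and compound 1 can be read from these two values. The furthest is compound 2, whose number lies beyond the scatter below that of compound 3.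

Compound 4 `O=c1c(CSC(=S)N2CCCC2)coc2ccccc12` has not yet been measured. It differs from compound 3 in one place: pyrrolidin-1-yl in place of morpholin-4-yl on a thiocarbonyl carbon. Compound 4 shares the pyrrolidin-1-yl group with compound 1 and compound 2, while its core carries none of the substituents found on those two compounds. Within the data shown here, no step between two measured compounds that differ in only one place is available, so the size of this change rests on an expectation alone.

The expected step in this assay from compound 3 to compound 4 is a 1.8-fold lower number from compound 3 to compound 4 (0.25 log units; within the scatter), a modest move toward a lower number. Compound 4 is therefore estimated at 2500 nM, with a range from 1200 nM to 5500 nM.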

Compound 4, half-maximal inhibitory concentration: 3600 nM
Compound 4: middle estimate off by 1.4-fold (0.16 log units), on the low side, and the stated range covers the measured number.
By their numbers in this assay, from the lowest: compounds 2, 1, 4 and 3 (each within the scatter of the next, the first and the last beyond it).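

In this assay the exchange of morpholin-4-yl for pyrrolidin-1-yl on a thiocarbonyl carbon now has a direct measure, a 1.2-fold lower number from compound 3 to compound 4 (0.09 log units; within the scatter), so this pair shows no separation between the two rings at this position. Among these compounds, compound 4 also gives the first one-place comparisons for the substituents on the aromatic carbons of the core, a 1.7-fold higher number from compound 2 to compound 4 (0.23 log units; within the scatter) and a 1.2-fold higher number from compound 1 to compound 4 (0.06 log units; within the scatter), and neither hydrogen in place of chloro nor hydrogen in place of methoxy moves the number outside the scatter. No measurement among the data speaks to why these steps are as small as they are.

As far as these compounds go, each of these steps rests on a single pair that includes compound 4, so it remains open whether chloro or methoxy on the core would read the same with morpholin-4-yl on the thiocarbonyl carbon. The compounds shown also leave open how a piperidin-1-yl ring or an open-chain diethylamino group would read at this position, and how a fluoro or nitro group would read on the aromatic carbon.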